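A few compounds are considered here, and "the series" means these few. Any claim that something is new, unique, unknown or untested is made for them only; others in the source may bear on it.

The series is built around a triazole core bearing an allyl group and a sulfur-linked side chain. Compound 1 `C=CCn1c(SC/C(=N/O)c2ccccc2)nnc1-c1ccc(OC)cc1` carries an oxime-type side chain; in a functional assay on the whole organism (strain albino) for inhibition, with Rattus norvegicus as the target, read by paw edema, with a stated time of 4 h, at a dose of 0.28 mmol/kg by the oral route (a higher number here means more inhibition at the dose given (going by the name of the read-out), a lower number less inhibition), compound 1 gives 76%. Compound 2 `C=CCn1c(SCC(=O)c2ccccc2)nnc1-c1ccc(OC)cc1` differs from compound 1 only in the side chain: a group of 8 heavy atoms (7 carbon, 1 oxygen; one six-membered aromatic ring of carbon only) in place of a group of 9 heavy atoms (7 carbon, 1 nitrogen, 1 oxygen; one six-membered aromatic ring of carbon only), on a saturated chain carbon bound to a sulfur. In this assay compound 2 gives 67%, so the change made a number 9 percentage points lower from compound 1 to compound 2 (within the scatter).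

Compound 3 `C=CCn1c(SC/C(=N/O)c2ccccc2)nnc1-c1cc(OC)c(OC)c(OC)c1` keeps the side chain of compound 1 but has a different aryl group on the core; the difference between the two cores is not broken down here. In this assay compound 3 gives 73%, and compound 1 and compound 3 lie within the scatter of each other, as do compound 3 and compound 2.

Compound 4 `C=CCn1c(SCC(=O)c2ccccc2)nnc1-c1cc(OC)c(OC)c(OC)c1` is not yet measured. It stands to compound 3 as compound 2 stands to compound 1: a group of 8 heavy atoms (7 carbon, 1 oxygen; one six-membered aromatic ring of carbon only) in place of a group of 9 heavy atoms (7 carbon, 1 nitrogen, 1 oxygen; one six-membered aromatic ring of carbon only), on a saturated chain carbon bound to a sulfur. The place is the same in both pairs, so this is the same change on a different core. Among the measured compounds shown here, since the one earlier instance of this change made a number 9 percentage points lower from compound 1 to compound 2 (within the scatter), compound 4 is expected to sit near compound 3 with a step of about a number 9 percentage points lower from compound 3 to compound 4 (within the scatter), a shift that stays inside the usual scatter. The estimate for compound 4 in this assay is 64%, with a range from 50% to 78%, resting on a single precedent and therefore held loosely.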

Compound 4, a percentage reported as inhibition, in the whole organism at one dose (the size of the read-out at that dose, not a potency): 66%
Compound 4: middle estimate off by 2 percentage points, on the low side, and the stated range covers the measured number.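

Putting benzoyl in place of the oxime-type group on the saturated chain carbon bound to a sulfur, on the core of compound 3, gives in this assay a number 7 percentage points lower from compound 3 to compound 4 (within the scatter). Set beside the earlier instance of the same change, the step carries over from one core to the other without any visible difference: the same change on two cores in this assay, a number 9 percentage points lower (within the scatter) from compound 1 to compound 2 and a number 7 percentage points lower (within the scatter) from compound 3 to compound 4, 2 percentage points apart, within the scatter of two such steps

This shows that, for these two cores and at this single dose and time, the change behaves alike, but it does not show that the oxime-type group truly gives more inhibition than benzoyl, since each step on its own stays inside the usual scatter, and two pairs support no rule for any other core.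

The compounds shown leave open how the read-out would respond if the side chain ended in an amine or a carboxylic acid, or if a longer chain linked the sulfur to the aromatic ring. They also leave open what a saturated propyl chain would do in place of the allyl group, and what an aryl group with no methoxy substituents would do on the core.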